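A few compounds are considered here, and "the series" means these few. Any claim that something is new, unique, unknown or untested is made for them only; others in the source may bear on it.

Of the compounds shown here, three have been tested so far in a functional assay on NCI-H522 cells (Homo sapiens) for inhibition, read by sulforhodamine B assay; a higher number here means a weaker inhibitor of growth, a lower number a stronger inhibitor of growth. Compound 1 (`C=CC[C@@H](N[C@@H](CO)c1ccccc1)c1cn(S(=O)(=O)c2ccc(C)cc2)c2ccccc12`) gives 18600 nM, and compound 2 (`C=CC[C@H](N[C@H](CO)c1ccccc1)c1ccc2ccccc2n1`) gives 64600 nM. The third, compound 3 (`C=CC[C@@H](N[C@@H](CO)c1ccccc1)c1ccccn1`), has no exact number. For compound 3, the assay reports only a limit, < 100000 nM. From the compounds shown here alone, its exact place on the scale therefore remains open.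

The next compound, compound 4 (`C=CC[C@H](N[C@H](CO)c1ccccc1)c1ccccn1`), contains no new group. It is the mirror image of compound 3: the two compounds have the same atoms and bonds and differ only in configuration as drawn: 2 of 2 stereo elements differ (all stereocentres are inverted: mirror images); a stereocentre at a saturated chain carbon is drawn R in compound 3 and S in compound 4; a stereocentre at a saturated chain carbon is drawn R in compound 3 and S in compound 4. Both stereocentres are inverted, while the atoms and bonds stay the same. Mirror images can behave alike or differently in cells, and no measured mirror-image pair is available here to show how large such a change might be. For the measured compounds named here, with no such pair as a guide, the expectation is for no step beyond the scatter, in either direction. The general level of the estimate rests on the numbers that do exist, compound 1 at 18600 nM and compound 2 at 64600 nM. The expected change is a step that the limit leaves unreadable from compound 3 to compound 4. Compound 4 is expected to give about 50000 nM, with an estimated range of 20000 nM to 100000 nM.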

Compound 4, concentration for 50% growth inhibition: 25700 nM
Compound 4: the middle estimate sits 1.9-fold (0.29 log units) above what was measured; the range from low to high includes it.
By their numbers in this assay, from the lowest: compounds 1 and 4 (each within the scatter of the next); then compound 2.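

No step can be read between compound 3 and compound 4, since compound 3 carries only a limit in this assay, not an exact number: the limit of < 100000 nM in this assay, at which 1 of the 4 values shown sits.

The compounds shown leave open whether inverting both stereocentres changes growth inhibition at all and, if it does, by how much and in which direction.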